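The source may report more compounds than this note shows. Statements on the series, on what has been measured and on what is new or still open speak of the compounds shown alone.

Three compounds share one core and differ only in the aryl group attached to an aromatic nitrogen of the five-membered ring. Compound 1 `COc1cccc(-n2cc(COc3cccc(NC(=O)Nc4ccc(Cl)c(C(F)(F)F)c4)c3)nn2)c1` carries a 3-methoxyphenyl there, and in a functional assay on HepG2 cells (Homo sapiens) for inhibition, read by MTT assay, with a stated time of 72 h (on this read-out lower numbers stand for stronger inhibition and higher numbers for weaker inhibition), compound 1 gives 1310 nM. Compound 2 `Cc1ccccc1-n1cc(COc2cccc(NC(=O)Nc3ccc(Cl)c(C(F)(F)F)c3)c2)nn1` carries a 2-methylphenyl, and in this assay compound 2 gives 3440 nM. Compound 3 `Cc1ccc(-n2cc(COc3cccc(NC(=O)Nc4ccc(Cl)c(C(F)(F)F)c4)c3)nn2)cc1` carries a 4-methylphenyl, and in this assay compound 3 gives 5430 nM, the highest number of the three. The step from compound 1 to compound 3 is a 4.1-fold higher number from compound 1 to compound 3 (0.62 log units; beyond the scatter), while the step from compound 2 to compound 3 is a 1.6-fold higher number from compound 2 to compound 3 (0.20 log units; within the scatter); the two methylphenyl variants are thus not separable, and only the 3-methoxyphenyl analogue stands clearly apart. Compound 4 `N#Cc1cccc(-n2cc(COc3cccc(NC(=O)Nc4ccc(Cl)c(C(F)(F)F)c4)c3)nn2)c1` is not yet measured. It differs from compound 3 as follows: 3-cyanophenyl in place of 4-methylphenyl on an aromatic nitrogen. Both steps toward compound 3 bear on this change, since each replaces one aryl substituent on that nitrogen with another; only the larger one, a 4.1-fold higher number from compound 1 to compound 3 (0.62 log units; beyond the scatter), went beyond the scatter. A modest step back toward a lower number is therefore expected. The estimated step from compound 3 to compound 4 in this assay is a 3.0-fold lower number from compound 3 to compound 4 (0.48 log units; beyond the scatter), so compound 4 is estimated at 1800 nM, within a range from 600 nM to 5400 nM.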

Compound 4, half-maximal inhibitory concentration: 2760 nM
Compound 4: middle estimate off by 1.5-fold (0.19 log units), on the low side, and the stated range covers the measured number.
By their numbers in this assay, from the lowest: compound 1; then compounds 4, 2 and 3 (each within the scatter of the next).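

In this assay, replacing either methylphenyl with 3-cyanophenyl gives a 2.0-fold lower number from compound 3 to compound 4 (0.29 log units; within the scatter) and a 1.2-fold lower number from compound 2 to compound 4 (0.10 log units; within the scatter), so compounds 2, 3 and 4 cannot be told apart, even though the nitrile brings a hydrogen-bond acceptor that the methylphenyl groups lack. The new comparison is between 3-methoxyphenyl and 3-cyanophenyl, where cyano in place of methoxy gives a 2.1-fold higher number from compound 1 to compound 4 (0.32 log units; beyond the scatter): the step is modest, but it shows that the change from methoxy to cyano on this aryl group is enough to move the number, so the separation of compound 1 does not come simply from the aryl group being a 3-substituted one. Nothing at hand gives a reason for this difference.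

The compounds shown leave open whether the result for compound 1 depends on where the methoxy sits, which a 2-methoxyphenyl or a 4-methoxyphenyl would address, and how a 3-methylphenyl would compare with both 3-substituted groups. Going by these compounds, what an amine or a carboxylic acid on this aryl ring would do also remains open.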